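The compounds below may be only part of what the source reports. "The series", "measured", "known", "first", "only" and "open" are said of these compounds alone.

Measured so far:
compound 1, `COc1ccc(-c2nc(-c3ccccc3C)no2)cc1`, 11.4%
compound 2, `Cc1ccc(-c2noc(-c3ccc(Cl)cc3)n2)cc1`, 20.6%

Both numbers come from an assay on HeLa cells for agonist activity at Bile acid receptor (Homo sapiens), read by a luciferase reporter, with a stated time of 24 h; on this read-out lower numbers stand for smaller maximal responses and higher numbers for larger maximal responses. Compound 1 gives the lower of the two numbers in this assay, but compound 2 sits within the usual scatter of it, so the two cannot be separated with any confidence. Within the data shown here, no pair of measured compounds differs in a single place, so no step of known size is available. Compound 3, `Cc1ccccc1-c1noc(-c2ccc(C(=O)O)cc2)n1`, is the next compound to be measured in this assay. Against compound 1 the change is carboxy in place of methoxy on an aromatic carbon. Among the measured compounds shown here, with no comparable step in hand, the expectation is only a small step upward in this assay, a number 8.6 percentage points higher from compound 1 to compound 3 (within the scatter), not clearly beyond the scatter. For compound 3 the estimated largest response in this assay is 20%, with a range from 5% to 45%.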

Compound 3, largest response reached (Emax), in percent of the reference or control that the assay uses: 16.2%
The estimate for compound 3 lay 3.8 percentage points above the measured number; measured number inside the range.
By their numbers in this assay, from the lowest: compounds 1, 3 and 2 (each within the scatter of the next).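

Carboxy in place of methoxy on an aromatic carbon, para to a large group, gives the first step of known size in this series, in this assay: a number 4.8 percentage points higher from compound 1 to compound 3 (within the scatter). At this position, a swap that brings in a hydrogen-bond donor and a double bond outside the aromatic rings therefore leaves the maximal response within the scatter, and the change cannot be told apart from no change. The data at hand offer no explanation for the size of this step.

On these data alone, whether an amine, a hydroxy group or a longer chain on the same aromatic carbon would move the response beyond the scatter remains open. Compound 2 differs from compound 1 and compound 3 in more than one place, so it gives no further reading of this position.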